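The source may report more compounds than this note shows. Statements on the series, on what has been measured and on what is new or still open speak of the compounds shown alone.

Compound 1 `CC1CCN(C2CCN(S(=O)(=O)c3cccc(-c4ccccc4C(F)(F)F)c3)CC2)CC1` is the starting point of this pair. Among the compounds with values here, in an ADME assay on S9 fraction from liver (Mus musculus, strain ICR/CD-1) for metabolic stability, read by LC-MS, using NADPH, with a stated time of 5 min, tested at 2 uM (on this read-out lower numbers stand for a shorter-lived compound and higher numbers for a longer-lived compound), compound 1 gives 0.617 h, the lowest of the two numbers measured so far. Within the data shown here, the one measured comparator is compound 2 `Cc1ccc(-c2cccc(S(=O)(=O)N3CCC(N4CCC(C)CC4)CC3)c2)cc1`, which in this assay gives 1.92 h; the step of a 3.1-fold higher number from compound 1 to compound 2 (0.49 log units; beyond the scatter) is the only measured step that bears on the change considered here.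

Compound 3 `COc1ccc(-c2cccc(S(=O)(=O)N3CCC(N4CCC(C)CC4)CC3)c2)cc1` is not yet measured. The change from compound 1 to compound 3 is 4-methoxyphenyl in place of 2-(trifluoromethyl)phenyl on an aromatic carbon. It resembles the change from compound 1 to compound 2 in that the same 2-(trifluoromethyl)phenyl is replaced, and in the same place, by a phenyl that carries a single small group, so a rise of similar size is the working expectation, with some allowance for the replacing group being different. The expected step is a 2.4-fold higher number from compound 1 to compound 3 (0.39 log units; beyond the scatter). Compound 3 is therefore estimated at 1.5 h, with a range from 0.6 h to 3.5 h.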

Compound 3, half-life: 2.4 h
Estimate against measurement, compound 3: 1.6-fold (0.20 log units) below; low and high end bracket the measured number.
By their numbers in this assay, from the lowest: compound 1; then compounds 2 and 3 (each within the scatter of the next).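

In this assay, 4-methoxyphenyl in place of 2-(trifluoromethyl)phenyl on this aromatic carbon gives a 3.9-fold higher number from compound 1 to compound 3 (0.59 log units; beyond the scatter), so the rise seen with compound 2 is not confined to the 4-methylphenyl group. Methoxy in place of methyl gives a 1.3-fold higher number from compound 2 to compound 3 (0.10 log units; within the scatter), so compound 2 and compound 3 cannot be told apart on this read-out, and this exchange of small groups has no readable effect here. No supporting data are available to explain the rise from compound 1.

Both replacements change the group on the phenyl and where it sits at the same time, so the compounds shown do not separate these two changes. On these data alone, the outcome with 4-(trifluoromethyl)phenyl, 2-methoxyphenyl, or an amine or carboxylic acid on this phenyl remains open.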